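A Larger Ring Replaces the Hydroxycyclobutylmethyl Group

A few compounds are considered here, and "the series" means these few. Any claim that something is new, unique, unknown or untested is made for them only; others in the source may bear on it.

Compound 2 `N#Cc1cnc(NCc2cnccc2C(F)(F)F)cc1NC[C@H]1C[C@H](O)C1` was tested in an assay on isolated protein for inhibition of protein kinase C delta type (Homo sapiens), read by TR-FRET, with a stated time of 2 h (on this read-out higher numbers stand for weaker inhibition and lower numbers for stronger inhibition), and gave > 10000 nM, which is a limit of the assay rather than a number. Compound 1 `N#Cc1cnc(NCc2cnccc2C(F)(F)F)cc1N[C@H]1C[C@@H](O)C1` likewise gave only a limit in this assay, > 10000 nM. Compound 3 `N#Cc1cnc(NCc2cnccc2C(F)(F)F)cc1NCC1CCOCC1` gave 5000 nM in this assay. From these values the step that the two limits leave unreadable from compound 1 to compound 2, while the step of an at least 2.0-fold lower number from compound 2 to compound 3 (0.30 log units; that floor lies within the scatter). Compound 4 `N#Cc1cnc(NCc2cnccc2C(F)(F)F)cc1N[C@H]1CC[C@@H](C(N)=O)CC1` differs from compound 2 by 4-carbamoylcyclohexyl in place of (3-hydroxycyclobutyl)methyl on a nitrogen on an aromatic ring. For the measured compounds named here, no measured step touches a carbamoyl group or a six-membered carbon ring, so the expected step of an at least 1.4-fold lower number from compound 2 to compound 4 (0.15 log units; that floor lies within the scatter) is small, with a real chance that this assay again reports only a limit. Compound 4 is therefore estimated at 7000 nM, between 2000 nM and 30000 nM.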

Compound 4, half-maximal inhibitory concentration: 400 nM
The estimate for compound 4 lay 18-fold (1.24 log units) above the measured number; the whole stated range lies above it.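

Placing 4-carbamoylcyclohexyl on this nitrogen gives a 13-fold lower number from compound 3 to compound 4 (1.10 log units; beyond the scatter), the first step in the series that is clearly beyond the scatter and so the first real sign that this position can change the reading. The same group also gives an at least 25-fold lower number from compound 2 to compound 4 (1.39 log units; beyond the scatter) and an at least 25-fold lower number from compound 1 to compound 4 (1.39 log units; beyond the scatter). These two sizes are floors, not exact sizes, set by a limit of the assay: the limit of > 10000 nM in this assay, at which 2 of the 4 values shown sit.

Going by these compounds, the six-membered carbon ring and the carbamoyl group enter together, so which of them carries the gain stays open. Also open, on these data alone, is how a carboxylic acid or an amine in place of the carbamoyl group would read.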